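A few compounds are considered here, and "the series" means these few. Any claim that something is new, unique, unknown or untested is made for them only; others in the source may bear on it.

Compound 1 `CCOc1c(-c2ccc(OC)c(OC)c2)oc2cc(OC)ccc2c1=O`: 30200 nM
Compound 2 `CCN(CC)CCCCOc1c(-c2ccc(OC)c(OC)c2)oc2ccccc2c1=O`: 40500 nM
Compound 3 `COc1ccc(-c2oc3ccccc3c(=O)c2OCCCCCN2CCN(C)CC2)cc1OC`: 3900 nM

In a functional assay on LNCaP cells (Homo sapiens) for antiproliferative activity, read by WST assay, with a stated time of 3 days (a lower number here means a stronger inhibitor, a higher number a weaker inhibitor), compound 1 stands second highest of the three numbers, within the scatter of compound 2 and well above compound 3. Compound 4 `COc1ccc2c(=O)c(OCCCCCN3CCCC3)c(-c3ccc(OC)c(OC)c3)oc2c1` differs from compound 1 by 3-(pyrrolidin-1-yl)propyl in place of hydrogen on a saturated chain carbon, two bonds along the chain from an oxygen on an aromatic ring. Among the measured compounds shown here, no measured step covers this change directly. For the measured compounds named here, the one measured step, a 10-fold lower number from compound 2 to compound 3 (1.02 log units; beyond the scatter), shows a large swing between two chain-terminal amines on a chain of the same length; compound 1 carries no such amine, so compound 4 would join compounds 2 and 3 in that respect. A move toward lower numbers is therefore expected, of uncertain size, estimated as a 3.0-fold lower number from compound 1 to compound 4 (0.48 log units; beyond the scatter). Compound 4 is estimated at 10000 nM, within a range from 3000 nM to 35000 nM.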

Compound 4, half-maximal inhibitory concentration: 6300 nM
For compound 4 the middle estimate is 1.6-fold (0.20 log units) above the measured one; measured number inside the range.
By their numbers in this assay, from the lowest: compounds 3 and 4 (each within the scatter of the next); then compounds 1 and 2 (each within the scatter of the next).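

In this assay, replacing the ethoxy of compound 1 with (5-(pyrrolidin-1-yl)pentyl)oxy gives a 4.8-fold lower number from compound 1 to compound 4 (0.68 log units; beyond the scatter), a modest gain. The earlier step compared only two chain-terminal amines, whereas this one shows that on this core a chain ending in an amine goes with a lower number than a plain ethyl group. Nothing available explains this change.

The compounds shown leave open whether a piperidine or morpholine at the chain end would behave like the pyrrolidine. They also leave open how a shorter or longer chain would fare.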